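A few compounds are considered here, and "the series" means these few. Any claim that something is new, unique, unknown or untested is made for them only; others in the source may bear on it.

Measured so far in a functional assay for agonist activity at Alpha-1D adrenergic receptor (Homo sapiens); a higher number here means that more compound is needed for the effect, a lower number that less compound is needed:
Compound 1, `CS(=O)(=O)c1ccc(F)cc1NCC1=NCCN1`: in this assay compound 1 gives < 100000 nM, which is a limit of the assay rather than a number.
Compound 2, `CSc1ccc(F)cc1NCC1=NCCN1`: in this assay compound 2 gives 21.9 nM.

Compound 2 thus holds the only actual number shown; the one other value is a limit. Among the compounds with values here, the single measured step, a step that the limit leaves unreadable from compound 1 to compound 2, cannot be read for size because of the limit of < 100000 nM in this assay, at which 1 of the 2 values shown sits, so it gives no usable scale for any further change.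

Compound 3, `CSc1ccc(Cl)cc1NCC1=NCCN1`, differs from compound 2 by chloro in place of fluoro on an aromatic carbon. Within the data shown here, no measured step exchanges one halogen for another, so nothing here points in either direction. The step of a 1.1-fold higher number from compound 2 to compound 3 (0.06 log units; within the scatter) is therefore expected to stay within the usual scatter. For compound 3 the value in this assay is estimated at 25 nM, with a range from 8 nM to 80 nM.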

Compound 3, half-maximal effective concentration: 2.69 nM
Beside the measured number, compound 3's estimate is 9.3-fold (0.97 log units) above it, and the stated range ends above it.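

Exchanging one halogen for another at this position, on the aromatic carbon para to the methylsulfanyl group, clearly matters: in this assay the change gives an 8.1-fold lower number from compound 2 to compound 3 (0.91 log units; beyond the scatter), so a single atom at this carbon moves the result. Within the data shown here, the only earlier step cannot be read, which makes this the first size of a change that the series offers, and it lies at a different place from that earlier step. Nothing measured here tells why chloro gives the lower number.

With only fluoro and chloro shown at this carbon, it stays open whether bromo, methyl, methoxy or an amine would give a lower or a higher number. Going by these compounds, it also stays open whether chloro would give a similar step with a group other than methylsulfanyl on the ring.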